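Working notes on compounds 1 to 3 in one series

The compounds below may be only part of what the source reports. "The series", "measured", "known", "first", "only" and "open" are said of these compounds alone.

Measured so far:
compound 1 `Cc1nc2cc(Cl)c(Cl)cc2n1C1CCCC1` — 40000 nM
compound 2 `CSc1nc2cc(Cl)c(Cl)cc2n1C1CCCC1` — 3900 nM

In a functional assay on MCF7 cells (Homo sapiens) for cytotoxicity, read by MTT assay, with a stated time of 48 h (a higher number here means a weaker inhibitor of growth, a lower number a stronger inhibitor of growth), compound 1 gives 40000 nM and compound 2 gives 3900 nM. Compound 2 holds the lowest of the two numbers; its nearest neighbour is compound 1, the step being a 10-fold lower number from compound 1 to compound 2 (1.01 log units; beyond the scatter). Compound 3 `CS(=O)(=O)c1nc2cc(Cl)c(Cl)cc2n1C1CCCC1` differs from compound 2 by methylsulfonyl in place of methylsulfanyl on an aromatic carbon. Among the measured compounds shown here, the one measured step, a 10-fold lower number from compound 1 to compound 2 (1.01 log units; beyond the scatter), concerns another exchange and does not bear directly on this one; no measured step covers this change. The step is expected to be a 1.5-fold higher number from compound 2 to compound 3 (0.19 log units; within the scatter), with wide uncertainty. Compound 3 is expected to give 6000 nM, within 1500 nM to 25000 nM.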

Compound 3, concentration for 50% growth inhibition: 600 nM
Beside the measured number, compound 3's estimate is 10-fold (1.00 log units) above it; the measured number lies below the stated range.
By their numbers in this assay, from the lowest: compound 3; then compound 2; then compound 1.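

At this position, on the aromatic carbon between two ring nitrogen atoms, the sulfur-bearing group still has room to change the read-out: in this assay methylsulfonyl in place of methylsulfanyl gives a further drop (a 6.5-fold lower number from compound 2 to compound 3 (0.81 log units; beyond the scatter)). Methylsulfonyl in place of methyl gives the largest change seen so far (a 67-fold lower number from compound 1 to compound 3 (1.82 log units; beyond the scatter)). Every step among compounds 1, 2 and 3 lies beyond the scatter, so their order is clear.

Open, on these data alone, is how an amine or a longer chain such as ethylsulfonyl would compare at this position. No supporting evidence is available to explain these steps.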